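The compounds below may be only part of what the source reports. "The series", "measured", "known", "first", "only" and "open" are said of these compounds alone.

Compound 1, `C=CC(=C)[C@@H](O)C[C@H]1C(=C)CC[C@@H]2[C@]1(C)CCC[C@]2(C)C(=O)O`, in a functional assay on HL-60 cells (Homo sapiens) for cytotoxicity, read by MTT assay, with a stated time of 48 h (on this read-out lower numbers stand for stronger inhibition and higher numbers for weaker inhibition), gives > 40000 nM; this is a limit of the assay.
Compound 2, `C=C1CC[C@@H]2[C@](C)(CCC[C@]2(C)C(=O)O)[C@H]1C/C=C(\C)C=O`, in this assay gives > 40000 nM; this too is a limit of the assay.

Among the measured compounds shown here, compound 2 therefore stands at the limit, and the one further value shown for this assay is also a limit. For the measured compounds named here, the single step between measured compounds, a step that the two limits leave unreadable from compound 1 to compound 2, cannot be sized because the limit of > 40000 nM in this assay, at which 2 of the 2 values shown sit, holds both of its ends.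

Compound 3 is `C=CC(=C)[C@H](O)C[C@H]1C(=C)CC[C@@H]2[C@]1(C)CCC[C@]2(C)C(=O)O`. It differs from compound 2 by a group of 6 heavy atoms (5 carbon, 1 oxygen; no ring) in place of a group of 5 heavy atoms (4 carbon, 1 oxygen; no ring), on a saturated chain carbon bound to a saturated ring carbon. Going by the values given here, the only measured step that bears on this change is the one from compound 1 to compound 2, which runs in the opposite direction through the same place and was left unreadable by the two limits. Among the compounds with values here, no step of readable size is therefore available, and nothing in the numbers points to a step beyond the scatter in either direction.

Compound 3 is thus expected to give 60000 nM, with a range from 20000 nM to 200000 nM, and most likely to be reported again only as a limit. This estimate means an expected step that the limit leaves unreadable from compound 2 to compound 3.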

Compound 3, half-maximal inhibitory concentration: > 40000 nM
Compound 3 gave a limit, no number (the forecaster's own chance of this, stated with the estimate: 85%); the middle value is on the limit's open side.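

No step linking compound 3 to compound 1 or compound 2 can be read, because each of these pairs has both ends at the same point: the limit of > 40000 nM in this assay, at which 3 of the 3 values shown sit.

The compounds shown leave open whether the configuration at the saturated chain carbon, or the 2-formylprop-1-en-1-yl group of compound 2, makes any difference in this assay.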